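A few compounds are considered here, and "the series" means these few. Any claim that something is new, unique, unknown or untested is made for them only; others in the source may bear on it.

Working notes on the series in an ADME assay on HS27 cells (Homo sapiens) for cytotoxicity, read by MTT assay, with a stated time of 24 h; on this read-out higher numbers stand for weaker inhibition of growth and lower numbers for stronger inhibition of growth. Compound 1 `Cc1ccc(NC(=O)C(c2ccc(Cl)cc2)c2ccc(Cl)cc2)cc1NC(=O)c1cnoc1C` gives > 30000 nM, which is a limit of the assay and not a number. Compound 2 `Cc1ccc(NC(=O)Nc2ccccc2F)cc1NC(=O)c1cnoc1C` gives > 30000 nM, also a limit. Going by the values given here, as the limit of > 30000 nM in this assay, at which 2 of the 2 values shown sit, shows, every value so far is this limit, so compound 2 stands at the limit and no measured step exists to scale from. Compound 3 `Cc1ccc(NC(=O)Nc2ccc(Cl)c(Cl)c2)cc1NC(=O)c1cnoc1C` shares the core of compound 2 and differs at one place, on an amide-type nitrogen: 3,4-dichlorophenyl in place of 2-fluorophenyl on an amide-type nitrogen. In words, 3,4-dichlorophenyl replaces 2-fluorophenyl. In this assay, the expectation is no step beyond the scatter, with any real shift running toward stronger inhibition of growth. The estimated change is an at least 1.2-fold lower number from compound 2 to compound 3 (0.07 log units; that floor lies within the scatter). For compound 3 the expected value is 25000 nM, with an estimated range from 10000 nM to 60000 nM.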

Compound 3, concentration for 50% growth inhibition: > 30000 nM
Compound 3 gave a limit, no number; the forecaster's own chance of this, stated with the estimate: 60%; at least 1.2-fold (0.07 log units) between middle value and limit.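

In this assay compound 3 gives > 30000 nM, a limit of the assay and not a number. Compound 2 also stands at a limit, so the step between compound 2 and compound 3 cannot be read. The compounds shown leave open whether any change on the shared core yields a measurable number in this assay.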